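Chromenone triazoles: benzyl ring variation on an inactive series

This account rests on a few compounds, and the source may have more. Where it says the series, first, only, none or still open, it means among the compounds named here.

Measured so far in a functional assay on MDA-MB-231 cells (Homo sapiens) for cytotoxicity, read by MTT assay, with a stated time of 48 h; a lower number here means a stronger inhibitor, a higher number a weaker inhibitor:
- compound 1 `O=c1ccoc2cc(OCc3cn(Cc4ccc(Cl)cc4)nn3)ccc12` gives > 100000 nM, a limit of the assay and not a number.
- compound 2 `O=c1ccoc2cc(OCc3cn(Cc4cccc(Br)c4)nn3)ccc12` gives > 100000 nM, likewise a limit and not a number.
- compound 3 `O=c1ccoc2cc(OCc3cn(Cc4cccc([N+](=O)[O-])c4)nn3)ccc12` gives > 100000 nM, again a limit and not a number.

Compound 2 stands at the limit, as do the two other values shown. All three compounds share the core of compound 1 and differ only in the substituted benzyl on the triazole. The steps between them, a step that the two limits leave unreadable from compound 1 to compound 2, a step that the two limits leave unreadable from compound 1 to compound 3 and a step that the two limits leave unreadable from compound 2 to compound 3, cannot be read in size or direction because the limit of > 100000 nM in this assay, at which 3 of the 3 values shown sit, holds every measured value at the same limit.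

Compound 4 `O=c1ccoc2cc(OCc3cn(Cc4ccc([N+](=O)[O-])cc4)nn3)ccc12` is not yet measured. Its change from compound 2 is 4-nitrophenyl in place of 3-bromophenyl on a saturated chain carbon bound to an aromatic nitrogen. The measured steps bear on it only insofar as each aryl substituent pattern tried so far, chloro, bromo and nitro, left the compound at the limit; a nitro in a different ring position has no readable step behind it. No step beyond the scatter is therefore expected, and compound 4 is most likely to return a limit as well.

Compound 4 is estimated at 150000 nM, range 50000 nM to 500000 nM, so that the expected step that the limit leaves unreadable from compound 2 to compound 4 is essentially none.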

Compound 4, half-maximal inhibitory concentration: 71300 nM
Estimate against measurement, compound 4: 2.1-fold (0.32 log units) above; measured number inside the range.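

In this assay, going by these compounds alone, compound 4 gives 71300 nM, a true number and not a limit, and it is the only such value: the limit of > 100000 nM in this assay, at which 3 of the 4 values shown sit. Set against the three limits, the 4-nitrophenyl group gives an at least 1.4-fold lower number from compound 3 to compound 4 (0.14 log units; that floor lies within the scatter), an at least 1.4-fold lower number from compound 2 to compound 4 (0.14 log units; that floor lies within the scatter) and an at least 1.4-fold lower number from compound 1 to compound 4 (0.14 log units; that floor lies within the scatter), the first of these being the cleanest comparison, since the nitro stays and only the ring pattern changes from 3-nitrophenyl to 4-nitrophenyl. Each of these floors lies within the scatter, so the result shows only that this place on the saturated chain carbon bound to an aromatic nitrogen can carry a group that reaches a measurable value, not that 4-nitrophenyl is established as better than the groups it replaces.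

As far as these compounds go, the steps among compound 1, compound 2 and compound 3 cannot be read, and the true size of all three new steps stays unknown while those compounds have limits and no numbers. Still open, from the compounds shown here alone, is whether an amine or a carboxylic acid in place of the nitro of compound 4, or a longer chain in place of the saturated chain carbon, would move the value beyond the scatter.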